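Acetylation of an aromatic amine on two related cores

The source may hold more compounds than are shown below. What is called first, only, known or untested is meant among the compounds shown, and "the series" means these compounds.

In a functional assay on K562/Adr cells (Homo sapiens) for inhibition, read by MTT assay, with a stated time of 48 h, tested at 30 uM (on this read-out higher numbers stand for more inhibition at the one concentration tested (going by the name of the read-out) and lower numbers for less inhibition), compound 1 `Nc1n[nH]c2cc(-c3cn([C@@H]4CN[C@H](C(=O)Nc5ccc(Cl)c(C(F)(F)F)c5)C4)nn3)ccc12` gives 48.2%. Compound 2 `CC(=O)Nc1n[nH]c2cc(-c3cn([C@@H]4CN[C@H](C(=O)Nc5ccc(Cl)c(C(F)(F)F)c5)C4)nn3)ccc12` carries acetyl in place of hydrogen on a nitrogen on an aromatic ring and in this assay gives 23.4%; the step of a number 24.8 percentage points lower from compound 1 to compound 2 (beyond the scatter) is a drop beyond the scatter. Compound 3 `Nc1nc2ccc(-c3cn([C@@H]4CN[C@H](C(=O)Nc5ccc(Cl)cc5Cl)C4)nn3)nc2s1` rests on a different core, and the difference between the two cores is not broken down here; in this assay compound 3 gives 42.2%, which lies within the scatter of compound 1. Compound 4 `CC(=O)Nc1nc2ccc(-c3cn([C@@H]4CN[C@H](C(=O)Nc5ccc(Cl)cc5Cl)C4)nn3)nc2s1` carries acetyl in place of hydrogen on a nitrogen on an aromatic ring relative to compound 3, the same change as that from compound 1 to compound 2, at a place described in the same words. Going by the values given here, because the only measured example of this change is the step of a number 24.8 percentage points lower from compound 1 to compound 2 (beyond the scatter), a step of similar size is expected for compound 4, namely a number 23.2 percentage points lower from compound 3 to compound 4 (beyond the scatter). Compound 4 is therefore estimated to give 19%, with a range from 5% to 36%.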

Compound 4, a percentage reported as inhibition, at one concentration (the size of the read-out at that concentration, not a potency): 36.1%
Estimate against measurement, compound 4: 17.1 percentage points below; the whole stated range lies below it.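

In this assay, replacing hydrogen with acetyl on the aromatic amine gives a number 6.1 percentage points lower from compound 3 to compound 4 (within the scatter). The change therefore does not carry over as a step of fixed size between these two pairs: the same change on two cores in this assay, a number 24.8 percentage points lower (beyond the scatter) from compound 1 to compound 2 and a number 6.1 percentage points lower (within the scatter) from compound 3 to compound 4, 18.7 percentage points apart, beyond the scatter of two such steps. Going by these compounds alone, this rests on only two pairs, which differ in the aryl group of the amide as well as in the core, so it does not show whether the core, that aryl group or both set the size of the step.

The compounds shown leave open how the two cores would compare with one identical aryl amide. They also leave open whether a propanoyl or methanesulfonyl group on the same amine would follow the acetyl step on either core.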